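Shared core series: nitro in place of methyl

The source may report more compounds than this note shows. Statements on the series, on what has been measured and on what is new or still open speak of the compounds shown alone.

Three members of the series have been run in a functional assay on HOP-62 cells (Homo sapiens) for cytotoxicity, read by sulforhodamine B assay, with a stated time of 48 h (on this read-out lower numbers stand for stronger inhibition of growth and higher numbers for weaker inhibition of growth), and each of them returned only a limit rather than a number. Compound 1 `Cc1cnc(NC(=O)COc2ccc(/C=C3\SC(=O)NC3=O)cc2)s1` gives < 100000 nM, which is a limit of the assay. Compound 2 `CCCCC1=NC2(CCCC2)C(=O)N1C(=O)COc1ccc(/C=C2/SC(=O)NC2=O)cc1` gives < 100000 nM, likewise a limit. Compound 3 `O=C(COc1ccc(/C=C2\SC(=O)NC2=O)cc1)Nc1cccc(C(F)(F)F)c1` gives < 100000 nM, again a limit. Where compound 1 stands among these can therefore not be told beyond (the limit of < 100000 nM in this assay, at which 3 of the 3 values shown sit); no ordering of the three is possible.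

Compound 4 `O=C(COc1ccc(/C=C2\SC(=O)NC2=O)cc1)Nc1ncc([N+](=O)[O-])s1` differs from compound 1 in one place: nitro in place of methyl on an aromatic carbon, read one bond further out as 5-methyl-1,3-thiazol-2-yl to 5-nitro-1,3-thiazol-2-yl. For the measured compounds named here, no measured step bears on this change, so no direction can be drawn from the data.

The expectation for compound 4 is a step that the limit leaves unreadable from compound 1 to compound 4 that stays within scatter, since compound 1 itself gives only < 100000 nM as a limit. The estimated value for compound 4 in this assay is 25000 nM, with a range from 4000 nM to 100000 nM, and a fair chance that only a limit is again reported.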

Compound 4, concentration for total growth inhibition: < 100000 nM
Compound 4: no number, only a limit; the forecaster's own chance of this, stated with the estimate: 55%; the middle value lies beyond the limit too.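

Compound 4, like compound 1, gives only a limit in this assay, so no step between them can be read: the limit of < 100000 nM in this assay, at which 4 of the 4 values shown sit.

On these data alone, whether nitro in place of methyl on an aromatic carbon changes growth inhibition at all remains open, as does any ordering of the four compounds.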